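This account rests on a few compounds, and the source may have more. Where it says the series, first, only, none or still open, it means among the compounds named here.

Measured compounds:
compound 1, `Cc1cc2nc(-c3cn(-c4ccccc4)nc3-c3ccccc3)[nH]c2cc1C`: > 50000 nM
compound 2, `Clc1ccc(-c2nn(-c3ccccc3)cc2-c2nc3cc(Cl)ccc3[nH]2)cc1`: 1170 nM
compound 3, `Cc1cc2nc(-c3cn(-c4ccccc4)nc3-c3ccc(Cl)cc3)[nH]c2cc1C`: 13000 nM

In a functional assay on MCF7 cells (Homo sapiens) for antiproliferative activity, read by MTT assay, with a stated time of 48 h (on this read-out lower numbers stand for stronger inhibition and higher numbers for weaker inhibition), compound 1 gives only a limit, > 50000 nM. Compound 3 differs from compound 1 by chloro in place of hydrogen on an aromatic carbon, and in this assay compound 3 gives 13000 nM, a step of an at least 3.8-fold lower number from compound 1 to compound 3 (0.58 log units; beyond the scatter). The size of this step is known only as a bound because compound 1 sits at the limit of > 50000 nM in this assay, at which 1 of the 3 values shown sits. The difference between the core of compound 2 and the core of compound 1 is not broken down here. In this assay compound 2 gives 1170 nM, the lowest number among the two numbers measured.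

Compound 4, `Clc1ccc(-c2nn(-c3ccccc3)cc2-c2nc3cc(Cl)c(Cl)cc3[nH]2)cc1`, has not yet been measured. It differs from compound 2 by chloro in place of hydrogen on an aromatic carbon. This is the same kind of change as that from compound 1 to compound 3, but not the same: there the chloro enters para to a large group, here on a ring that is part of a fused system of two rings, ortho to a chloro group. The step from compound 2 to compound 4 is expected to be a 1.7-fold lower number from compound 2 to compound 4 (0.22 log units; within the scatter), resting on an at least 3.8-fold lower number from compound 1 to compound 3 (0.58 log units; beyond the scatter), though the place of the chloro differs. Compound 4 is estimated at 700 nM, between 200 nM and 3000 nM.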

Compound 4, half-maximal inhibitory concentration: 48300 nM
Beside the measured number, compound 4's estimate is 69-fold (1.84 log units) below it; the measured number lies above the stated range.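

In this assay, chloro in place of hydrogen on an aromatic carbon does not carry over from one core to the other, for the new step is a 41-fold higher number from compound 2 to compound 4 (1.62 log units; beyond the scatter). Set beside the earlier step, it runs the opposite way, and the gap between the two is beyond the scatter: the same change on two cores in this assay, an at least 3.8-fold lower number (0.58 log units; beyond the scatter) from compound 1 to compound 3 and a 41-fold higher number (1.62 log units; beyond the scatter) from compound 2 to compound 4, at least 150-fold (2.20 log units) apart, beyond the scatter of two such steps What this does not show is whether the core or the place of the chloro decides the outcome, for the two changes differ in both, and the earlier step is known only as a bound: the limit of > 50000 nM in this assay, at which 1 of the 4 values shown sits.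

The compounds shown leave open whether another group at the place taken by the new chloro, such as a methoxy group, an amine or a carboxylic acid, would read like chloro on the core of compound 2. For the compounds shown here, they also leave open whether the result for compound 4 depends on the chloro group ortho to the new one, as no compound here carries the new chloro without it.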